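Methoxy in Place of Nitro on the Benzyl Ether Series

A few compounds are considered here, and "the series" means these few. Any claim that something is new, unique, unknown or untested is made for them only; others in the source may bear on it.

Measured compounds:
compound 1, `c1ccc(COc2nc3ccccc3s2)cc1`: 68.8%
compound 2, `O=[N+]([O-])c1ccc(COc2nc3ccccc3s2)cc1`: 4.39%

In a functional assay on the whole organism with Mus musculus as the target, with a stated time of 1 h, at a dose of 100 mg/kg by the intraperitoneal route (on this read-out higher numbers stand for more inhibition at the one dose given (going by the name of the read-out) and lower numbers for less inhibition), compound 2 stands lowest of the two numbers available. Among the compounds with values here, its nearest neighbour is compound 1, and the only measured step, a number 64.4 percentage points lower from compound 1 to compound 2 (beyond the scatter), separates them. Compound 3, `COc1ccc(COc2nc3ccccc3s2)cc1`, has not yet been measured. It differs from compound 2 by methoxy in place of nitro on an aromatic carbon. Within the data shown here, the one step that bears on this change is the step from compound 1 to compound 2, since it is the same nitro group, now leaving, that entered there and went with a large fall in this assay. Among the measured compounds shown here, whether the methoxy that replaces it behaves like hydrogen or like nitro cannot be read from the numbers at hand; no methoxy analogue has been measured. The reasonable expectation is that removing the nitro returns much of what was lost, while the methoxy adds an unknown part. Compound 3 is therefore expected to rise by a number 40.6 percentage points higher from compound 2 to compound 3 (beyond the scatter), landing at an estimated 45%, within a range of 10% to 80%, in this assay.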

Compound 3, a percentage reported as inhibition, in the whole organism at one dose (the size of the read-out at that dose, not a potency): 2.43%
Compound 3: the middle estimate sits 42.6 percentage points above what was measured; measured number below the stated range.
By their numbers in this assay, from the lowest: compounds 3 and 2 (each within the scatter of the next); then compound 1.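

In this assay, the change of methoxy in place of nitro on an aromatic carbon, para to a large group, is a number 2 percentage points lower from compound 2 to compound 3 (within the scatter), so this assay does not tell the two groups apart at this position. Methoxy in place of hydrogen on the same carbon gives a number 66.4 percentage points lower from compound 1 to compound 3 (beyond the scatter), a large step of the same kind as a number 64.4 percentage points lower from compound 1 to compound 2 (beyond the scatter), which shows that the loss is not particular to nitro: both groups placed here go with it, while compound 1, with hydrogen at this carbon, reads 68.8% in the same assay. Nothing at hand explains why these two different groups give such similar readings.

The compounds shown leave open whether any group at this carbon keeps the level of compound 1, or whether a fluorine, a methyl, an amine or a carboxylic acid there would go with the same fall. They also leave open how these compounds would compare at other doses, since the read-out gives the size of the effect at one dose only and is not a potency.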